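A Larger Alkoxy Pattern on a Weak Growth Inhibitor

The compounds below may be only part of what the source reports. "The series", "measured", "known", "first", "only" and "open" are said of these compounds alone.

- Compound 1 `CCOc1ccc(/C=C(\C(=O)c2ccc(Cl)cc2)S(=O)(=O)Cc2ccc(F)cc2)cc1OC` gives 50000 nM
- Compound 2 `CCOc1ccc(/C=C(/SCc2ccc(C)cc2)C(=O)c2ccc(Cl)cc2)cc1OC` gives 25000 nM
- Compound 3 `COc1ccc(/C=C(\C(=O)c2ccc(Cl)cc2)S(=O)(=O)Cc2ccccc2Cl)cc1` gives 50000 nM

In a functional assay on DU-145 cells (Homo sapiens) for inhibition, read by trypan blue exclusion, with a stated time of 96 h (a lower number here means a stronger inhibitor of growth, a higher number a weaker inhibitor of growth), compound 3 gives 50000 nM, level with compound 1 at the digits shown. Together these two hold the highest number of the three, while compound 2 gives 25000 nM, and all three lie within the scatter of one another.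

The next compound is compound 4 `CCOc1ccc(/C=C(\C(=O)c2ccc(Cl)cc2)S(=O)(=O)Cc2ccccc2Cl)cc1OC`, which carries 4-ethoxy-3-methoxyphenyl in place of 4-methoxyphenyl on a double-bonded chain carbon bound to a double-bonded chain carbon. Within the data shown here, no measured step changes this group alone. Among the measured compounds shown here, the only single-place step available is a 2.0-fold lower number from compound 1 to compound 2 (0.30 log units; within the scatter), made elsewhere in the molecule, so it bears on this change only indirectly. The entering group is already present in compound 1, which gives 50000 nM, the same number as compound 3, although the two also differ in their benzyl groups. In this assay no step beyond the scatter is therefore expected, and the estimated step is a 1.1-fold lower number from compound 3 to compound 4 (0.05 log units; within the scatter). For compound 4 the estimated value is 45000 nM, with an expected range from 20000 nM to 80000 nM.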

Compound 4, concentration for 50% growth inhibition: 10000 nM
Compound 4: the middle estimate sits 4.5-fold (0.65 log units) above what was measured, outside the stated range (below it).
By their numbers in this assay, from the lowest: compound 4; then compounds 2, 1 and 3 (each within the scatter of the next).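

In this assay, among these compounds, 4-ethoxy-3-methoxyphenyl in place of 4-methoxyphenyl gives a 5.0-fold lower number from compound 3 to compound 4 (0.70 log units; beyond the scatter), so this place on the double-bonded chain carbon can shift the number beyond the scatter, which the only earlier step did not do. The entering group does not do this alone: 2-chlorophenyl in place of 4-fluorophenyl on a saturated chain carbon bound to a sulfonyl sulfur gives a 5.0-fold lower number from compound 1 to compound 4 (0.70 log units; beyond the scatter), and (2-chlorobenzyl)sulfonyl in place of (4-methylbenzyl)sulfanyl gives a 2.5-fold lower number from compound 2 to compound 4 (0.40 log units; beyond the scatter), so among these compounds the lower number appears only where 4-ethoxy-3-methoxyphenyl and the 2-chlorobenzyl sulfonyl group stand together, as in compound 4. Nothing measured here offers a reason for these steps.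

The compounds shown leave open how much of the step from 4-methoxyphenyl belongs to the added methoxy group and how much to the ethoxy group, as the two enter together. They also leave open whether a longer chain such as propoxy, or an amine at the same place on the ring, would carry the number lower still.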